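The compounds below may be only part of what the source reports. "The series", "measured", "known", "first", "only" and "open" are said of these compounds alone.

In an ADME assay on microsomes from liver (Rattus norvegicus) for metabolic stability, read by LC-MS, using NADPH, with a stated time of 10 min, tested at 0.5 uM (a lower number here means that less of the compound is left, a higher number that more of the compound is left), compound 1 `COC(=O)Nc1cc(-c2ccc(OC[C@@](C)(N)CC(C)C)cn2)ccn1` gives 100% and compound 2 `COC(=O)Nc1cc(-c2cc(C)c(OC[C@@](C)(N)CC(C)C)cn2)ccn1` gives 100%, so these two stand level. Compound 3 `COC(=O)Nc1cc(-c2cnc(OC[C@@](C)(N)CC(C)C)c(C#N)c2)ccn1` gives 80%, a clearly lower number. Compound 4 `Cc1cc(-c2cc(C)c(OC[C@@](C)(N)CC(C)C)cn2)ccn1` comes from compound 2 through a single structural change: methyl in place of (methoxycarbonyl)amino on an aromatic carbon. In words, this is methyl in place of (methoxycarbonyl)amino on an aromatic carbon.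

Within the data shown here, the only measured step available as a guide is no change at the digits printed from compound 1 to compound 2 (within the scatter), which lies within the scatter. That step also swaps hydrogen for methyl and leaves the (methoxycarbonyl)amino group untouched. All three measured compounds carry this group, so no measurement shows what happens when it is removed. With compound 2 already at 100%, the number has little room to rise, and with compound 3 at 80%, lower numbers clearly occur in this series. The expected change is therefore a moderate fall of uncertain size, estimated as a number 15 percentage points lower from compound 2 to compound 4 (beyond the scatter). For compound 4 the estimated value is 85%, with an expected range from 60% to 100%.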

Compound 4, percent of the compound remaining: 72%
Compound 4: middle estimate off by 13 percentage points, on the high side; measured number inside the range.
By their numbers in this assay, from the lowest: compounds 4 and 3 (each within the scatter of the next); then compounds 1 and 2 (each within the scatter of the next).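

In this assay, among these compounds, putting methyl in place of (methoxycarbonyl)amino gives a number 28 percentage points lower from compound 2 to compound 4 (beyond the scatter), the first measured change at this position. The earlier compounds shown here all carried the (methoxycarbonyl)amino group, so they could not show that the number depends on what sits on this aromatic carbon, next to the ring nitrogen. The result shows that this group cannot be swapped for methyl without a real loss of remaining compound in this pair, yet nothing shown here explains the fall.

With only methyl as the replacement, the compounds shown cannot separate losing the (methoxycarbonyl)amino group from gaining the methyl. As far as these compounds go, it also remains open whether a simple amine or an acetamide at this position would stay level with compound 2.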